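The source may hold more compounds than are shown below. What is called first, only, known or untested is meant among the compounds shown, and "the series" means these compounds.

The measured compounds in an assay on Prostate gland for inhibition of steroid 5-alpha-reductase (Rattus norvegicus); on this read-out higher numbers stand for weaker inhibition and lower numbers for stronger inhibition:
compound 1 `C/C(=C\C(=O)Nc1ccccc1OCCCC(=O)O)c1ccc2c(ccn2CC(C)C)c1`: 160 nM
compound 2 `CCCCC(CCCC)n1ccc2cc(/C(C)=C/C(=O)Nc3ccccc3OCCCC(=O)O)ccc21`: 21 nM
compound 3 `CCCC(c1ccccc1)n1ccc2cc(/C(C)=C/C(=O)Nc3ccccc3OCCCC(=O)O)ccc21`: 9.1 nM

Compound 3 gives the lowest number of the three, with a 2.3-fold lower number from compound 2 to compound 3 (0.36 log units; beyond the scatter) and an 18-fold lower number from compound 1 to compound 3 (1.25 log units; beyond the scatter) both beyond the scatter. Compound 4 `C/C(=C\C(=O)Nc1ccccc1OCCCC(=O)O)c1ccc2c(ccn2C(c2ccccc2)c2ccc(C(F)(F)F)cc2)c1` differs from compound 3 in one place: 4-(trifluoromethyl)phenyl in place of propyl on a saturated chain carbon bound to an aromatic carbon and an aromatic nitrogen. Going by the values given here, the steps that bear on this are those leading into compound 3, where exchanging an alkyl substituent on the aromatic nitrogen for one bearing a phenyl gave an 18-fold lower number from compound 1 to compound 3 (1.25 log units; beyond the scatter) and a 2.3-fold lower number from compound 2 to compound 3 (0.36 log units; beyond the scatter). Among the compounds with values here, compound 4 again exchanges an alkyl part for an aromatic one on that same chain carbon, so a further modest lowering in this assay is expected, though no measured pair shows this particular replacement and the step could fall within the scatter. For compound 4 the estimated value is 5 nM, with a range of 1.5 nM to 20 nM, meaning an expected step of a 1.8-fold lower number from compound 3 to compound 4 (0.26 log units; within the scatter).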

Compound 4, half-maximal inhibitory concentration: 8.1 nM
The estimate for compound 4 lay 1.6-fold (0.21 log units) below the measured number; the range from low to high includes it.
By their numbers in this assay, from the lowest: compounds 4 and 3 (each within the scatter of the next); then compound 2; then compound 1.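

In this assay, putting 4-(trifluoromethyl)phenyl in place of propyl gives a 1.1-fold lower number from compound 3 to compound 4 (0.05 log units; within the scatter). The earlier exchanges of the group on the aromatic nitrogen each moved the number beyond the scatter, whereas this one, on the saturated chain carbon, does not, even though the entering group has 10 heavy atoms and the leaving group 3. Nothing available explains this result. The compounds shown leave open what a plain propyl-free pair would show with an amine or a methoxy group in place of the trifluoromethyl, and whether a longer chain at this carbon would give a different number.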